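Adding a trifluoromethylphenyl group to a non-cytotoxic core

The compounds below may be only part of what the source reports. "The series", "measured", "known", "first", "only" and "open" are said of these compounds alone.

Compound 1 `Cc1nc(C(=O)NCc2ccccc2)c(O)c(=O)n1C` is the starting point of this step. In an ADME assay on HepG2 cells (Homo sapiens) for cytotoxicity, in the presence of a further agent that is not named here (on this read-out lower numbers stand for stronger inhibition and higher numbers for weaker inhibition), compound 1 gives > 100000 nM, which is a limit of the assay rather than a measured number. Two related compounds end the same way. Compound 2 `CN(Cc1ccccc1)C(=O)c1nc(Cc2ccccc2C(F)(F)F)n(C)c(=O)c1O` gives > 100000 nM in this assay, again a limit. Compound 3 `COc1c(C(=O)NCc2ccccc2)nc(Cc2ccccc2C(F)(F)F)n(C)c1=O` gives > 100000 nM in this assay, also a limit. Every value shown therefore sits at one and the same place: the limit of > 100000 nM in this assay, at which 3 of the 3 values shown sit. Compound 1 thus stands level with the other measured compounds, and no number separates any of them.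

Compound 4 `Cn1c(Cc2ccccc2C(F)(F)F)nc(C(=O)NCc2ccccc2)c(O)c1=O` has not yet been measured in this assay. It differs from compound 1 in a single place: 2-(trifluoromethyl)phenyl in place of hydrogen on a saturated chain carbon bound to an aromatic carbon. Going by the values given here, no step between measured compounds is available to gauge what such a change does to cytotoxicity, so the only guide is that all three measured compounds sit at the same limit. The expected step, a step that the limit leaves unreadable from compound 1 to compound 4, is none beyond the usual scatter in either direction. Compound 4 is expected to give 150000 nM, within a range from 60000 nM to 400000 nM, and the most likely outcome is that the assay again reports only a limit.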

Compound 4, half-maximal inhibitory concentration: > 100000 nM
Compound 4: no number, only a limit; the forecaster's own chance of this, stated with the estimate: 85%; the middle value lies beyond the limit too.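

Compound 4 ends where compound 1, compound 2 and compound 3 ended: the limit of > 100000 nM in this assay, at which 4 of the 4 values shown sit. Going by these compounds alone, these are limits rather than numbers, and no step from any of those three compounds to compound 4 can be read. The compounds shown leave open how strongly each would inhibit the cells beyond that limit, and whether any of these changes matters.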